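Replacing the chloropyridinyl sulfonamide: what a bromopyridinyl brings

A few compounds are considered here, and "the series" means these few. Any claim that something is new, unique, unknown or untested is made for them only; others in the source may bear on it.

Compound 1 `O=S(=O)(O)CSc1nnc(Br)n1Cc1ccc(Br)c2ccccc12` gives 14400 nM in an assay on HEK293 cells for inhibition of solute carrier family 22 member 12 (Homo sapiens); a lower number here means a stronger inhibitor, a higher number a weaker inhibitor.
Compound 2 `O=S(=O)(CSc1nnc(Br)n1Cc1ccc(Br)c2ccccc12)Nc1cccnc1` gives 32 nM in this assay.
Compound 3 `O=S(=O)(CSc1nnc(Br)n1Cc1ccc(Br)c2ccccc12)Nc1cccnc1Cl` gives 5100 nM in this assay.

Compound 3 sits second highest of the three numbers: its nearest neighbour is compound 1, as a 2.8-fold lower number from compound 1 to compound 3 (0.45 log units; beyond the scatter) shows, while compound 2 lies far below it, as a 160-fold higher number from compound 2 to compound 3 (2.20 log units; beyond the scatter) shows. Compound 4 `O=S(=O)(CSc1nnc(Br)n1Cc1ccc(Br)c2ccccc12)Nc1ccc(Br)nc1` is the next structure, and it differs from compound 3 by 6-bromopyridin-3-yl in place of 2-chloropyridin-3-yl on a sulfonamide nitrogen.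

Within the data shown here, three measured steps bear on this change. Replacing the hydroxy on the sulfonyl sulfur by the plain pyridinylamino gave a 450-fold lower number from compound 1 to compound 2 (2.65 log units; beyond the scatter), whereas the chloropyridinylamino gave only a 2.8-fold lower number from compound 1 to compound 3 (0.45 log units; beyond the scatter); the single chloro on the ring thus cost a 160-fold higher number from compound 2 to compound 3 (2.20 log units; beyond the scatter). Compound 4 keeps a substituted pyridinyl, but with bromo at a different named place and no substituent at the place where chloro stood. Among the measured compounds shown here, no measured compound carries a bromo on that ring, so the size of its effect is unknown. The expectation is that compound 4 recovers part of the potency of compound 2 without reaching it, a step of a 26-fold lower number from compound 3 to compound 4 (1.41 log units; beyond the scatter). Compound 4 is estimated at 200 nM, within a range from 30 nM to 2000 nM.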

Compound 4, half-maximal inhibitory concentration: 2200 nM
For compound 4 the middle estimate is 11-fold (1.04 log units) below the measured one, outside the stated range (above it).
By their numbers in this assay, from the lowest: compound 2; then compound 4; then compound 3; then compound 1.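

In this assay, exchanging 2-chloropyridin-3-yl for 6-bromopyridin-3-yl on a sulfonamide nitrogen gives only a 2.3-fold lower number from compound 3 to compound 4 (0.37 log units; beyond the scatter), so taking the halogen away from the place chloro held does not restore the potency of the unsubstituted pyridinyl. A halogen at this other place is also costly, with a 69-fold higher number from compound 2 to compound 4 (1.84 log units; beyond the scatter), and the gain over hydroxy on the sulfonyl sulfur stays small at a 6.5-fold lower number from compound 1 to compound 4 (0.82 log units; beyond the scatter); among the three amino groups compared, both halogen-bearing rings therefore lose most of the large gain seen with the plain pyridinyl of compound 2. Nothing in the data shown accounts for the cost of either halogen.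

Compound 3 and compound 4 differ in both the halogen and its place on the ring, so the contribution of each cannot be separated. Going by these compounds, it remains open whether a fluoro, a methyl or an amine on the pyridinyl ring would stay close to compound 2 or fall back towards compound 3 and compound 4.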